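This account rests on a few compounds, and the source may have more. Where it says the series, first, only, none or still open, it means among the compounds named here.

Measured so far in an ADME assay on HaCaT cells (Homo sapiens) for inhibition, read by sulforhodamine B assay, with a stated time of 48 h; a lower number here means a stronger inhibitor of growth, a higher number a weaker inhibitor of growth:

Compound 1, `O=C1C=COC(/C=C/c2ccccc2)C1`: 127 uM
Compound 2, `COc1ccc(/C=C/c2cc(=O)cco2)cc1OC`: 690 uM
Compound 3, `COc1ccc(C2CC(=O)C=CO2)cc1`: 264 uM

Of the three numbers, compound 3 holds the second highest. Its nearest neighbour is compound 1, whose number is lower by more than the usual scatter; compound 2 lies furthest off, with a number higher than that of compound 3, again beyond the scatter. Compound 3 thus sits in the middle of a spread that is real but not wide.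

Compound 4, `COc1ccc(C2CC(=O)C(Br)=CO2)cc1`, has not yet been measured. It differs from compound 3 in a single way: bromo in place of hydrogen on a double-bonded ring carbon. Among the compounds with values here, no pair of measured compounds shows this change, so the size of its effect in this assay is not known from the data at hand. The three measured numbers span a modest range, and a single small change is taken here to move the number by a step of similar or smaller size, most likely toward a lower number. The step from compound 3 to compound 4 is estimated at a 1.8-fold lower number from compound 3 to compound 4 (0.25 log units; within the scatter). Compound 4 is accordingly expected to give about 150 uM, within a range from 60 uM to 400 uM.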

Compound 4, concentration for growth inhibition (reported as GI): 164 uM
Estimate against measurement, compound 4: 1.1-fold (0.04 log units) below; the measured number falls inside the stated range.
By their numbers in this assay, from the lowest: compounds 1, 4 and 3 (each within the scatter of the next, the first and the last beyond it); then compound 2.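

In this assay, bromo in place of hydrogen on a double-bonded ring carbon gives a 1.6-fold lower number from compound 3 to compound 4 (0.21 log units; within the scatter), the only step among these compounds that isolates a single change. Within the data shown here, the double-bonded ring carbon two ring bonds from the ring oxygen therefore accepts a bromo without a shift beyond the usual scatter, something the earlier compounds, which differ in more than one place, could not show. Nothing available accounts for the size of this step or explains the result.

Going by these compounds, whether a smaller halogen such as chloro, or an amine or a carboxylic acid, would leave the number as little changed on this same carbon remains open. So does whether bromo at this carbon would behave alike on the cores of compound 1 and compound 2.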